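The compounds below may be only part of what the source reports. "The series", "measured", "known", "first", "only" and "open" are said of these compounds alone.

Measured so far in an assay for inhibition of histone deacetylase 8 (Homo sapiens), read by fluorescence, with a stated time of 3 h; a higher number here means that more compound is needed for the effect, a lower number that less compound is needed:
compound 1 `COc1ccc(NS(=O)(=O)c2cccc(/C=C/C(=O)NO)c2)cc1` gives 167 nM
compound 2 `O=C(/C=C/c1cccc(S(=O)(=O)N2CCN(c3ccccn3)CC2)c1)NO` gives 581 nM
compound 3 `O=C(/C=C/c1nc2ccccc2o1)NO` gives 573 nM

Compound 2 has the highest of the three numbers in this assay. Compound 3 sits within the usual scatter of it, so the two cannot be ordered. Compound 1 lies beyond the scatter, with a lower number than compound 2. Compound 4 `COc1ccccc1N1CCN(S(=O)(=O)c2cccc(/C=C/C(=O)NO)c2)CC1` is not yet measured; it differs from compound 2 by 2-methoxyphenyl in place of pyridin-2-yl on an amine nitrogen in a ring. Going by the values given here, no measured pair shows this same change, so no step can be quoted for it. The entering 2-methoxyphenyl, like the leaving pyridin-2-yl, carries one hydrogen-bond acceptor and no donor, and the author expects no step beyond the scatter, or at most a small one toward a lower number, so that a 1.3-fold lower number from compound 2 to compound 4 (0.11 log units; within the scatter) is the estimated step. For compound 4 the expected value in this assay is 450 nM, in a range from 150 nM to 1400 nM.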

Compound 4, concentration for half-maximal effect: 328 nM
For compound 4 the middle estimate is 1.4-fold (0.14 log units) above the measured one; low and high end bracket the measured number.
By their numbers in this assay, from the lowest: compounds 1, 4, 3 and 2 (each within the scatter of the next, the first and the last beyond it).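

In this assay, going by these compounds alone, putting 2-methoxyphenyl in place of pyridin-2-yl on an amine nitrogen in a ring gives a 1.8-fold lower number from compound 2 to compound 4 (0.25 log units; within the scatter) and is the first change here made at a single place. At this position, an aromatic ring of carbon only bearing a methoxy group can thus stand in for the pyridin-2-yl ring without a step beyond the scatter. Nothing available explains this result. Still open, on these data alone, is whether a non-aromatic group on that nitrogen, such as methyl or acetyl, would also stay within the scatter of compound 2. A carboxylic acid on the aromatic ring is equally untested by the compounds shown here.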